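Anilide variation on a shared core with no readable steps

The source may report more compounds than this note shows. Statements on the series, on what has been measured and on what is new or still open speak of the compounds shown alone.

Compound 1 `O=C(COc1ccc2cc(/C=C3/SC(=O)NC3=O)ccc2c1)Nc1ccc(F)cc1F` and compound 2 `O=C(COc1ccc2cc(/C=C3/SC(=O)NC3=O)ccc2c1)Nc1c(F)cc(F)cc1Br` share one core and differ only in the aryl group on the amide-type nitrogen. In an assay on isolated protein for inhibition of histone deacetylase 8 (Homo sapiens), with a stated time of 1 h (on this read-out lower numbers stand for stronger inhibition and higher numbers for weaker inhibition), compound 1 gives > 50000 nM, which is a limit of the assay and not a number. Compound 2 likewise gives > 50000 nM in this assay, again a limit. The step that the two limits leave unreadable from compound 1 to compound 2 therefore cannot be sized, since the limit of > 50000 nM in this assay, at which 2 of the 2 values shown sit, places both recorded values at the same limit. Compound 3 `O=C(COc1ccc2cc(/C=C3/SC(=O)NC3=O)ccc2c1)Nc1cc(Cl)cc(C(F)(F)F)c1` carries 3-chloro-5-(trifluoromethyl)phenyl in place of 2-bromo-4,6-difluorophenyl on an amide-type nitrogen. For the measured compounds named here, no measured step has a readable size, so neither direction nor magnitude can be drawn from the pair; both recorded values rest at the limit, and compound 3 is expected to rest there as well. Compound 3 is estimated at 60000 nM, within 20000 nM to 200000 nM, most probably reported again as a limit. The implied step that the limit leaves unreadable from compound 2 to compound 3 is expected to be none beyond the scatter.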

Compound 3, half-maximal inhibitory concentration: > 50000 nM
Compound 3: only a limit was reported (the forecaster's own chance of this, stated with the estimate: 85%); the middle value lies beyond the limit too.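

No step can be read among compound 1, compound 2 and compound 3 in this assay, since the recorded results are limits and not numbers: the limit of > 50000 nM in this assay, at which 3 of the 3 values shown sit.

The compounds shown leave open whether any aryl group on the amide-type nitrogen of the shared core gives a measurable inhibition.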